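The compounds below may be only part of what the source reports. "The series", "measured", "known", "first", "only" and "open" are said of these compounds alone.

Working notes on the series, read in an in vivo ADME assay on the whole organism (Cavia porcellus); a higher number here means that the compound lasts longer, a lower number that the compound disappears faster. Compound 1 (`CCC(NC(=O)c1ccc(C(=N)N)cc1)C(C)(C)C(=O)N1CCC(CC(=O)O)CC1`) gives 1.3 h, compound 2 (`CCCCCC(NC(=O)c1ccc(C(=N)N)cc1)C(C)(C)C(=O)N1CCC(CC(=O)O)CC1`) gives 0.517 h, and compound 3 (`CC(C)(C(=O)N1CCC(CC(=O)O)CC1)C(NC(=O)c1ccc(C(=N)N)cc1)c1ccc2ccccc2c1`) gives 0.85 h. Compound 2 stands at the low end of these numbers, but compound 3 lies within the scatter of it, as a 1.6-fold higher number from compound 2 to compound 3 (0.22 log units; within the scatter) shows. Only compound 1 is clearly apart, with a 2.5-fold lower number from compound 1 to compound 2 (0.40 log units; beyond the scatter).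

The next compound to be measured is compound 4 (`CC(C)(C(=O)N1CCC(CC(=O)O)CC1)C(NC(=O)c1ccc(C(=N)N)cc1)c1cccc(O)c1`). It carries 3-hydroxyphenyl in place of pentyl on a saturated chain carbon bound to an amide-type nitrogen and a saturated chain carbon.

Going by the values given here, two measured steps bear on this change. The nearest is the replacement of pentyl by naphthalen-2-yl in compound 3, the step already given, which stays within the scatter. The replacement of ethyl by naphthalen-2-yl, a 1.5-fold lower number from compound 1 to compound 3 (0.18 log units; within the scatter), also stays within it. Among the compounds with values here, no measured compound carries 3-hydroxyphenyl, so the contribution of the hydroxyl is unknown.

No step beyond the scatter is therefore expected in this assay, and the expected direction, if any, is upward, on the precedent of compound 3 at 0.85 h. The expected step is a 1.5-fold higher number from compound 2 to compound 4 (0.16 log units; within the scatter). The estimate for compound 4 is 0.75 h, with an expected range from 0.4 h to 1.4 h.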

Compound 4, half-life: 1.08 h
Estimate against measurement, compound 4: 1.4-fold (0.16 log units) below, and the stated range covers the measured number.
By their numbers in this assay, from the lowest: compounds 2, 3, 4 and 1 (each within the scatter of the next, the first and the last beyond it).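

In this assay, this position now gives a step beyond the scatter when a ring-bearing group replaces pentyl: a 2.1-fold higher number from compound 2 to compound 4 (0.32 log units; beyond the scatter), modest in size, whereas the naphthalen-2-yl replacement of pentyl stayed within the scatter. The exchange of naphthalen-2-yl for 3-hydroxyphenyl gives a 1.3-fold higher number from compound 3 to compound 4 (0.10 log units; within the scatter), so these two groups cannot be told apart here, and the replacement of ethyl by 3-hydroxyphenyl gives a 1.2-fold lower number from compound 1 to compound 4 (0.08 log units; within the scatter), so those two cannot be told apart either. Pentyl is thus the only group at this carbon with steps beyond the scatter, to both compound 1 and compound 4, although compound 3 remains within the scatter of compound 2.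

Nothing in the data shown gives a reason for these differences. The contribution of the hydroxyl remains open, since the compounds shown include neither plain phenyl nor a ring carrying methoxy or an amine in place of the hydroxyl, and it also remains open whether a chain longer than pentyl would extend the step seen from compound 1 to compound 2.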